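Sulfonyl for sulfanyl on a shared diaryl amide core

This account rests on a few compounds, and the source may have more. Where it says the series, first, only, none or still open, it means among the compounds named here.

Measured so far:
compound 1 `O=C(Nc1ccc([N+](=O)[O-])c(C(F)(F)F)c1)c1ccc(Sc2ccc(O)cc2)cc1` — 5190 nM
compound 2 `O=C(Nc1cc(C(F)(F)F)ccc1C(F)(F)F)c1ccc(Sc2ccc(O)cc2)cc1` — 10900 nM
compound 3 `O=C(Nc1ccc([N+](=O)[O-])c(C(F)(F)F)c1)c1ccc(S(=O)(=O)c2ccc(O)cc2)cc1` — 8570 nM

Of the compounds shown here, three have been tested in a functional assay on VCaP cells (Homo sapiens) for antiproliferative activity, read by fluorescence and propidium iodide staining, with a stated time of 96 h; a higher number here means a weaker inhibitor, a lower number a stronger inhibitor. Compound 1 `O=C(Nc1ccc([N+](=O)[O-])c(C(F)(F)F)c1)c1ccc(Sc2ccc(O)cc2)cc1` gives 5190 nM. Compound 3 `O=C(Nc1ccc([N+](=O)[O-])c(C(F)(F)F)c1)c1ccc(S(=O)(=O)c2ccc(O)cc2)cc1` differs from it by (4-hydroxyphenyl)sulfonyl in place of (4-hydroxyphenyl)sulfanyl on an aromatic carbon, and in this assay compound 3 gives 8570 nM; the step is a 1.7-fold higher number from compound 1 to compound 3 (0.22 log units; within the scatter). Compound 2 `O=C(Nc1cc(C(F)(F)F)ccc1C(F)(F)F)c1ccc(Sc2ccc(O)cc2)cc1` carries a different core; how its core differs from that of compound 1 is not broken down here. In this assay compound 2 gives 10900 nM, a number that stands beyond the scatter only against compound 1.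

Compound 4 `O=C(Nc1cc(C(F)(F)F)ccc1C(F)(F)F)c1ccc(S(=O)(=O)c2ccc(O)cc2)cc1` has not yet been measured. It stands to compound 2 as compound 3 stands to compound 1: the difference is (4-hydroxyphenyl)sulfonyl in place of (4-hydroxyphenyl)sulfanyl on an aromatic carbon, and the place is the same in both pairs. Because the earlier step was a 1.7-fold higher number from compound 1 to compound 3 (0.22 log units; within the scatter), a step of similar size is expected here, estimated at a 1.5-fold higher number from compound 2 to compound 4 (0.17 log units; within the scatter). On that basis compound 4 is expected to give about 16000 nM in this assay, with a likely range from 8000 nM to 35000 nM.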

Compound 4, half-maximal inhibitory concentration: 30500 nM
Estimate against measurement, compound 4: 1.9-fold (0.28 log units) below; the measured number falls inside the stated range.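

On the core of compound 2, putting (4-hydroxyphenyl)sulfonyl in place of (4-hydroxyphenyl)sulfanyl gives a 2.8-fold higher number from compound 2 to compound 4 (0.45 log units; beyond the scatter) in this assay, so the sulfonyl compound again carries the higher number. Taken alone, this step lies beyond the scatter, while the step on the core of compound 1 lies within it, but two pairs on two cores cannot establish a rule for the whole series or explain why the number rises. Within these two pairs, the change carries over from one core to the other in the same direction, and the two step sizes cannot be told apart: the same change on two cores in this assay, a 1.7-fold higher number (0.22 log units; within the scatter) from compound 1 to compound 3 and a 2.8-fold higher number (0.45 log units; beyond the scatter) from compound 2 to compound 4, 1.7-fold (0.23 log units) apart, within the scatter of two such steps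

The compounds shown leave open how the same exchange behaves on cores where a nitrile or a chlorine takes the place of the nitro or trifluoromethyl groups. They also leave open what happens when an amine or a carboxylic acid replaces the hydroxyl group, or when a sulfinyl or carbonyl link replaces the sulfur-based links.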